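A few compounds are considered here, and "the series" means these few. Any claim that something is new, unique, unknown or untested is made for them only; others in the source may bear on it.

Measured so far:
compound 1 `COc1ccc(/C=C/C(=O)NCCCC(C)Nc2cc(OC)cc3cccnc23)cc1` — in an ADME assay on L6 cells (Rattus norvegicus) for cytotoxicity, read by resazurin assay, with a stated time of 70 h (on this read-out higher numbers stand for weaker inhibition and lower numbers for stronger inhibition), compound 1 gives > 240000 nM, which is a limit of the assay and not a number.
compound 2 `COc1cc(NC(C)CCCNC(=O)NNC(=O)/C=C/c2ccccc2F)c2ncccc2c1` — in this assay compound 2 gives 25100 nM.

Compound 2 holds the only actual number shown in this assay; the other value is the limit of > 240000 nM in this assay, at which 1 of the 2 values shown sits. Among the measured compounds shown here, no step between measured compounds that differ in one place can therefore be drawn, and of compound 1 and compound 2 only what the two values show can be said.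

The next compound is compound 3 `COc1cc(NC(C)CCCNC(=O)NNC(=O)Nc2cccc(C(F)(F)F)c2)c2ncccc2c1`. Relative to compound 2 the change is (3-(trifluoromethyl)phenyl)amino in place of 2-(2-fluorophenyl)ethenyl on a carbonyl carbon. Nothing measured in the series speaks directly to this kind of change, so the expectation rests on compound 2 alone. In this assay a shift towards weaker inhibition is expected, a 1.8-fold higher number from compound 2 to compound 3 (0.25 log units; within the scatter), with a result inside the usual scatter also quite possible. Compound 3 is estimated at 45000 nM, with a range from 12000 nM to 170000 nM.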

Compound 3, half-maximal inhibitory concentration: 32100 nM
Compound 3: the middle estimate sits 1.4-fold (0.15 log units) above what was measured, within the range that was stated.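

In this assay, (3-(trifluoromethyl)phenyl)amino in place of 2-(2-fluorophenyl)ethenyl on a carbonyl carbon gives a 1.3-fold higher number from compound 2 to compound 3 (0.11 log units; within the scatter). Among the compounds shown here, this is the first step that can be read, and at this position the two compounds do not separate, although the entering group brings a nitrogen and a hydrogen-bond donor and the leaving group takes its double bond outside aromatic rings with it. Both groups hold one six-membered aromatic ring of carbon only, so for this pair the link to that ring can differ without a difference beyond the scatter.

Steps to compound 1 cannot be read because its value is a limit of the assay and not a number: the limit of > 240000 nM in this assay, at which 1 of the 3 values shown sits. Still open is whether a group without an aromatic ring on this carbonyl carbon, such as an amine, a carboxylic acid or a longer alkyl chain, would give a number beyond the scatter of compound 3.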